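Growing the ring amine substituent in a bradykinin antagonist series

The source may hold more compounds than are shown below. What is called first, only, known or untested is meant among the compounds shown, and "the series" means these compounds.

Three compounds have so far been measured in an in vitro functional assay on cells for antagonist activity at B1 bradykinin receptor (Homo sapiens), read by luminescence and calcium flux, with a stated time of 2 h; on this read-out higher numbers stand for weaker inhibition and lower numbers for stronger inhibition:

compound 1, `Cc1ccc(S(=O)(=O)N2C=CNC(=O)[C@H]2CC(=O)NC2CCOCC2(C)C)cc1`: 25.2 nM
compound 2, `Cc1ccc(S(=O)(=O)N2C=CNC(=O)[C@H]2CC(=O)N[C@H]2CCN(C)CC2(C)C)cc1`: 0.42 nM
compound 3, `CCN1CC[C@H](NC(=O)C[C@@H]2C(=O)NC=CN2S(=O)(=O)c2ccc(C)cc2)C(C)(C)C1`: 0.63 nM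

Compound 3 gives the second highest of the three numbers. It sits close to compound 2, as the step of a 1.5-fold higher number from compound 2 to compound 3 (0.18 log units; within the scatter) lies within the scatter, and far from compound 1, as a 40-fold lower number from compound 1 to compound 3 (1.60 log units; beyond the scatter) shows.

Compound 4, `Cc1ccc(S(=O)(=O)N2C=CNC(=O)[C@H]2CC(=O)N[C@H]2CCN(CC(C)C)CC2(C)C)cc1`, differs from compound 3 only by isopropyl in place of methyl on a saturated chain carbon bound to an amine nitrogen in a ring. For the measured compounds named here, the one measured step that bears on this place, a 1.5-fold higher number from compound 2 to compound 3 (0.18 log units; within the scatter), stayed within the scatter. The large steps of a 60-fold lower number from compound 1 to compound 2 (1.78 log units; beyond the scatter) and a 40-fold lower number from compound 1 to compound 3 (1.60 log units; beyond the scatter) concern a different change and do not speak to this one. With a single small precedent, compound 4 is expected to show a 1.6-fold higher number from compound 3 to compound 4 (0.20 log units; within the scatter), nothing beyond the scatter. The estimate for compound 4 is therefore 1 nM, with a range from 0.3 nM to 3.5 nM.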

Compound 4, half-maximal inhibitory concentration: 0.86 nM
For compound 4 the middle estimate is 1.2-fold (0.07 log units) above the measured one; the range from low to high includes it.
By their numbers in this assay, from the lowest: compounds 2, 3 and 4 (each within the scatter of the next, the first and the last beyond it); then compound 1.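

At this place, on a saturated chain carbon bound to an amine nitrogen in a ring, isopropyl in place of methyl gives a 1.4-fold higher number from compound 3 to compound 4 (0.14 log units; within the scatter), so the chain can grow from methyl to isopropyl with no step beyond the scatter. Only the full comparison with hydrogen at this place gives a 2.0-fold higher number from compound 2 to compound 4 (0.31 log units; beyond the scatter), a modest step. No evidence bearing on this result is available.

The compounds shown leave open whether a longer chain would keep the number this low. They also leave open what a phenyl ring or a carboxylic acid would do at this place.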